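Methylating the Urea Nitrogen of a Macrocycle-Free Protease Inhibitor

The source may hold more compounds than are shown below. What is called first, only, known or untested is meant among the compounds shown, and "the series" means these compounds.

Compound 3 `C=C[C@@H]1C[C@]1(NC(=O)[C@@H]1C[C@@H](Oc2cc(-c3ccccc3)nc3cc(OC)ccc23)CN1C(=O)[C@@H](NC(=O)NC(C)(C)C)C(C)(C)C)C(=O)NS(=O)(=O)C1CC1` gives the lowest number of the three measured compounds in an ADME assay on the whole organism (plasma, Rattus norvegicus, strain Sprague-Dawley) for pharmacokinetics, read by LC-MS, with a stated time of 4 h, at a dose of 15 mg/kg by the intraduodenal route (a lower number here means less compound in the circulation, a higher number more compound in the circulation at the dose given), at 17 ng.h/mL. Compound 2 `C=C[C@@H]1C[C@]1(NC(=O)[C@@H]1C[C@@H](Oc2cc(-c3ccccc3)nc3cc(OC)ccc23)CN1C(=O)[C@@H](NC(=O)OC(C)(C)C)C(C)(C)C)C(=O)NS(=O)(=O)C1CC1` gives 61 ng.h/mL, and compound 1 `C=C[C@@H]1C[C@]1(NC(=O)[C@@H]1C[C@@H](Oc2nccc3cc(OC)ccc23)CN1C(=O)[C@@H](NC(=O)N[C@H](COC)C(C)(C)C)C(C)(C)C)C(=O)NS(=O)(=O)C1CC1`, which carries a different core, gives 3280 ng.h/mL. Going by the values given here, the only step between neighbours is a 3.6-fold lower number from compound 2 to compound 3 (0.55 log units; beyond the scatter). Compound 4 `C=C[C@@H]1C[C@]1(NC(=O)[C@@H]1C[C@@H](Oc2cc(-c3ccccc3)nc3cc(OC)ccc23)CN1C(=O)[C@@H](NC(=O)N(C)C(C)(C)C)C(C)(C)C)C(=O)NS(=O)(=O)C1CC1` differs from compound 3 by methyl in place of hydrogen on an amide-type nitrogen. Among the compounds with values here, no measured step touches the amide-type nitrogen, so that step from compound 2 to compound 3 bears only loosely on the change. The account therefore expects a step from compound 3 to compound 4 of a 1.5-fold higher number from compound 3 to compound 4 (0.17 log units; within the scatter) in this assay, within the scatter. Compound 4 is estimated to give 25 ng.h/mL, within 6 ng.h/mL to 100 ng.h/mL.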

Compound 4, area under the concentration-time curve: 32 ng.h/mL
Compound 4: middle estimate off by 1.3-fold (0.11 log units), on the low side; measured number inside the range.
By their numbers in this assay, from the lowest: compounds 3, 4 and 2 (each within the scatter of the next, the first and the last beyond it); then compound 1.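

In this assay, methyl in place of hydrogen on the amide-type nitrogen gives a 1.9-fold higher number from compound 3 to compound 4 (0.27 log units; within the scatter), so adding this one carbon at this position moves the number by no more than repeat measurements would. With methyl(tert-butyl)amino in place of tert-butoxy on the carbonyl carbon the result is a 1.9-fold lower number from compound 2 to compound 4 (0.28 log units; within the scatter), whereas the step with (tert-butyl)amino, a 3.6-fold lower number from compound 2 to compound 3 (0.55 log units; beyond the scatter), lay beyond the scatter. Nothing available accounts for these numbers. As far as these compounds go, whether ethyl or a longer chain on this nitrogen would read the same in this assay stays open, as does whether methyl here would do the same on the core of compound 1.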